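Replacing the Hydroxymethyl Group on the Shared Core

A few compounds are considered here, and "the series" means these few. Any claim that something is new, unique, unknown or untested is made for them only; others in the source may bear on it.

Compound 1 `CCOCc1nc(Nc2ccc(C(F)(F)F)cc2)c2ccc(-c3ncccc3C(F)(F)F)cc2n1` and compound 2 `CC(C)OCc1nc(Nc2ccc(C(F)(F)F)cc2)c2ccc(-c3ncccc3C(F)(F)F)cc2n1` share their core with compound 3 `OCCc1nc(Nc2ccc(C(F)(F)F)cc2)c2ccc(-c3ncccc3C(F)(F)F)cc2n1`. In a functional assay for antagonist activity at transient receptor potential cation channel subfamily V member 1 (Homo sapiens) (a higher number here means a weaker inhibitor, a lower number a stronger inhibitor), compound 1 gives 0.9 nM, compound 2 gives 0.3 nM, and compound 3 gives 22 nM, the highest of the three numbers. The gaps are large: a 24-fold higher number from compound 1 to compound 3 (1.39 log units; beyond the scatter) and a 73-fold higher number from compound 2 to compound 3 (1.87 log units; beyond the scatter). Compound 4 `FC(F)(F)c1ccc(Nc2nc(CNC3CCCCC3)nc3cc(-c4ncccc4C(F)(F)F)ccc23)cc1` differs from compound 3 by cyclohexylamino in place of hydroxymethyl on a saturated chain carbon bound to an aromatic carbon. Both measured steps away from the hydroxymethyl group moved the number far downward, though neither introduced a nitrogen-bearing group, so the size of the coming step is uncertain. A large downward step is nonetheless expected, a 7.3-fold lower number from compound 3 to compound 4 (0.87 log units; beyond the scatter). Compound 4 is estimated at 3 nM in this assay, within a range of 0.6 nM to 15 nM.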

Compound 4, half-maximal inhibitory concentration: 6 nM
Estimate against measurement, compound 4: 2.0-fold (0.30 log units) below; the measured number falls inside the stated range.
By their numbers in this assay, from the lowest: compound 2; then compound 1; then compound 4; then compound 3.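

In this assay, a group carrying a nitrogen and a six-membered carbon ring at this place still gives a lower number than hydroxymethyl, with a 3.7-fold lower number from compound 3 to compound 4 (0.56 log units; beyond the scatter) as the step. Against ethoxy and isopropoxy, however, cyclohexylamino falls short, with a 6.7-fold higher number from compound 1 to compound 4 (0.82 log units; beyond the scatter) and a 20-fold higher number from compound 2 to compound 4 (1.30 log units; beyond the scatter) as the steps. Nothing available here accounts for these differences.

Going by these compounds, it remains open whether the gap to the ethers follows the nitrogen or the ring. Cyclohexyloxy would separate the two, and a small amine such as methylamino would test the nitrogen without the ring.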